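A few compounds are considered here, and "the series" means these few. Any claim that something is new, unique, unknown or untested is made for them only; others in the source may bear on it.

Working notes on the series. In an assay for binding affinity to adenosine receptor A1 (Rattus norvegicus), in the presence of a further agent that is not named here (a higher number here means a weaker inhibitor, a lower number a stronger inhibitor), compound 1 `Cn1c(=O)[nH]c2cc[nH]c2c1=O` gives 2900 nM. In this assay compound 2 `CCCn1c(=O)c2[nH]ccc2n(CCC)c1=O` gives 440 nM, and compound 3 `CCCn1c(=O)c2c(ccn2C)n(CCC)c1=O` gives 2300 nM. Among the measured compounds shown here, the single step between two compounds that differ in one place is a 5.2-fold higher number from compound 2 to compound 3 (0.72 log units; beyond the scatter). Compound 3 therefore stands second highest of the three numbers: compound 1 lies nearest, within the scatter, and compound 2 lies furthest, beyond it.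

Compound 4 `CCCn1c(=O)c2c(cc(-c3ccccc3)n2C)n(CCC)c1=O` differs from compound 3 in one place: phenyl in place of hydrogen on an aromatic carbon. For the measured compounds named here, no measured step involves a phenyl group, nor any change at an aromatic carbon; the only measured step, a 5.2-fold higher number from compound 2 to compound 3 (0.72 log units; beyond the scatter), concerns a methyl on an aromatic nitrogen and does not speak to a phenyl entering at a ring carbon. With nothing in the measured set bearing directly on this change, the expectation for this assay is no step beyond the scatter in either direction, and the estimate is anchored on compound 3 at 2300 nM with a wide range to reflect the missing precedent. Compound 4 is expected to give 2300 nM, within 500 nM to 10000 nM. The estimate means a step of no change at the digits printed from compound 3 to compound 4 (within the scatter).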

Compound 4, inhibition constant: 110 nM
Beside the measured number, compound 4's estimate is 21-fold (1.32 log units) above it, and the stated range ends above it.
By their numbers in this assay, from the lowest: compound 4; then compound 2; then compounds 3 and 1 (each within the scatter of the next).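

In this assay, among the compounds shown here, phenyl in place of hydrogen on an aromatic carbon gives a 21-fold lower number from compound 3 to compound 4 (1.32 log units; beyond the scatter), the first measured change at a ring carbon of the shared core, and it shows that this carbon of the five-membered aromatic ring, next to the ring nitrogen and next to the ring atom that bears a methyl group, can take a group of 6 heavy atoms with a large move to a lower number. For the compounds shown here, the only earlier step, a 5.2-fold higher number from compound 2 to compound 3 (0.72 log units; beyond the scatter), ran towards a higher number at the ring nitrogen, so the series now holds one change that raises the number and one at a different place that lowers it, and the methyl on the nitrogen does not stop the lower number from being reached. No measured evidence on the origin of this step is available.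

Going by these compounds, it remains open whether a methyl, a chlorine or a pyridyl at this ring carbon, or a phenyl carrying an amine or a carboxylic acid, would give a step of similar size. On these data alone, it is also open whether phenyl at this carbon would act the same way on the core of compound 2, which has hydrogen on the ring nitrogen.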